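Replacing (Propylcarbonyl)oxy with Fluoro

A few compounds are considered here, and "the series" means these few. Any claim that something is new, unique, unknown or untested is made for them only; others in the source may bear on it.

Of the compounds shown here, two have been measured so far in a functional assay on DLD-1 cells (Homo sapiens) for cytotoxicity, with a stated time of 48 h; on this read-out higher numbers stand for weaker inhibition and lower numbers for stronger inhibition. Compound 1 `C[S+]([O-])/C=C/c1cc(=O)c2ccccc2o1` gives 8000 nM, and compound 2 `CCCC(=O)Oc1ccc2oc(/C=C/[S+](C)[O-])cc(=O)c2c1` gives 8700 nM. These two values lie within the usual scatter of repeated measurements, so compound 2 cannot be ranked against compound 1 on these numbers.

The next structure is compound 3 `C[S+]([O-])/C=C/c1cc(=O)c2cc(F)ccc2o1`, which carries fluoro in place of (propylcarbonyl)oxy on an aromatic carbon. Going by the values given here, only one measured step bears on this change, since it concerns the group that now leaves. That step, a 1.1-fold higher number from compound 1 to compound 2 (0.04 log units; within the scatter), brought in (propylcarbonyl)oxy in place of hydrogen and stayed within the scatter. Among the compounds with values here, no measured compound yet carries fluoro, so this single small step is the only guide, and it is thin evidence. On that basis, no step beyond the scatter is expected in this assay. The expected step is a 1.1-fold lower number from compound 2 to compound 3 (0.04 log units; within the scatter). For compound 3 the estimated value is 8000 nM, with an expected range from 3500 nM to 18000 nM.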

Compound 3, half-maximal inhibitory concentration: 7000 nM
Estimate against measurement, compound 3: 1.1-fold (0.06 log units) above, within the range that was stated.
By their numbers in this assay, from the lowest: compounds 3, 1 and 2 (each within the scatter of the next).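

In this assay the swap to fluoro gives (a 1.2-fold lower number from compound 2 to compound 3 (0.09 log units; within the scatter)), and fluoro in place of hydrogen on the same aromatic carbon gives (a 1.1-fold lower number from compound 1 to compound 3 (0.06 log units; within the scatter)), so neither step can be told apart from repeat-measurement noise. Until now this carbon had been seen with only two substituents, hydrogen and (propylcarbonyl)oxy; with fluoro there are three, and they range from a group of 6 heavy atoms with 2 hydrogen-bond acceptors to a single fluorine atom with none, yet compounds 1, 2 and 3 cannot be ranked against one another in this cell assay, which suggests that, across these three groups, the read-out does not follow the size of the substituent or its count of acceptors. No supporting measurement bears on why these numbers stay so close together.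

The compounds shown leave open whether an amine or a carboxylic acid on this aromatic carbon, or a longer chain in place of the propyl part of the ester, would produce a step beyond the scatter. They also leave open whether a change elsewhere on the shared core would do so.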